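Para substituent swap on the aryl ring: chloro to bromo

The source may report more compounds than this note shows. Statements on the series, on what has been measured and on what is new or still open speak of the compounds shown alone.

Compound 1, `C=CC(=O)Nc1cc(Nc2ncc3ncn(-c4ccccc4)c3n2)c(OC)cc1N(C)CCN(C)C`, gives 8080 nM in an ADME assay on HT-29 cells (Homo sapiens) for cytotoxicity, read by MTT assay, with a stated time of 72 h; on this read-out higher numbers stand for weaker inhibition and lower numbers for stronger inhibition.
Compound 2, `C=CC(=O)Nc1cc(Nc2ncc3ncn(-c4ccc(C)cc4)c3n2)c(OC)cc1N(C)CCN(C)C`, gives 9230 nM in this assay.
Compound 3, `C=CC(=O)Nc1cc(Nc2ncc3ncn(-c4ccc(Cl)cc4)c3n2)c(OC)cc1N(C)CCN(C)C`, gives 7690 nM in this assay.

The three numbers cannot be told apart: the steps of a 1.1-fold higher number from compound 1 to compound 2 (0.06 log units; within the scatter), a 1.1-fold lower number from compound 1 to compound 3 (0.02 log units; within the scatter) and a 1.2-fold lower number from compound 2 to compound 3 (0.08 log units; within the scatter) all lie within the scatter, so compound 3 is not separable from compound 1 or compound 2 in this assay.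

Compound 4, `C=CC(=O)Nc1cc(Nc2ncc3ncn(-c4ccc(Br)cc4)c3n2)c(OC)cc1N(C)CCN(C)C`, differs from compound 3 in one place: bromo in place of chloro on an aromatic carbon. Within the data shown here, the steps that bear on this are the two that change the same position, a 1.1-fold lower number from compound 1 to compound 3 (0.02 log units; within the scatter) and a 1.2-fold lower number from compound 2 to compound 3 (0.08 log units; within the scatter); both were within the scatter, as was a 1.1-fold higher number from compound 1 to compound 2 (0.06 log units; within the scatter). Hydrogen, methyl and chloro at this position therefore gave no step beyond the scatter, and the move to bromo is expected to behave in the same way, with no step in this assay beyond the scatter in either direction. The expected step is a 1.0-fold higher number from compound 3 to compound 4 (0.00 log units; within the scatter). Compound 4 is estimated at 7700 nM, with a range from 3900 nM to 15500 nM.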

Compound 4, half-maximal inhibitory concentration: 1460 nM
The estimate for compound 4 lay 5.3-fold (0.72 log units) above the measured number; measured number below the stated range.
By their numbers in this assay, from the lowest: compound 4; then compounds 3, 1 and 2 (each within the scatter of the next).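

In this assay, among these compounds, the position para to a large group, flat across hydrogen, methyl and chloro, responds to bromo, which gives a 5.3-fold lower number from compound 3 to compound 4 (0.72 log units; beyond the scatter) in the single change of 4-chlorophenyl to 4-bromophenyl. The separation appears against the other two groups as well, as a 6.3-fold lower number from compound 2 to compound 4 (0.80 log units; beyond the scatter) and as a 5.5-fold lower number from compound 1 to compound 4 (0.74 log units; beyond the scatter) so compound 4 stands apart from all three earlier compounds and not from just one of them. Nothing available explains why the two halogens part here.

The compounds shown leave open whether this response is particular to bromo or also appears with iodo, an amine, a carboxylic acid or a longer chain at this position. Also open, from the compounds shown here alone, is whether bromo elsewhere on the same ring would give a step of this size.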